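This account rests on a few compounds, and the source may have more. Where it says the series, first, only, none or still open, it means among the compounds named here.

Working notes on the series.

Compound 3 `C[C@H](CC(=O)O)CC(=O)c1c(CCCCCCc2ccccc2)n(C)c2ccc(Cl)cc12` gives the lowest number of the three measured in a functional assay for antagonist activity at Oxoeicosanoid receptor 1 (Homo sapiens), read by fluorescence and calcium flux, with stated times of 2 min and 1 min (on this read-out lower numbers stand for stronger inhibition and higher numbers for weaker inhibition), at 0.12 nM. Its nearest neighbour on the numbers is compound 1 `C[C@H](CC(=O)O)CC(=O)c1c([C@@H](O)CCCCCc2ccccc2)n(C)c2ccc(Cl)cc12`, which in this assay gives 0.38 nM; furthest is compound 2 `C[C@@H](CC(=O)O)CC(=O)c1c([C@H](O)CCCCCc2ccccc2)n(C)c2ccc(Cl)cc12`, which gives 750 nM.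

The step to compound 4 `C[C@H](CC(=O)O)CC(=O)c1c([C@H](O)CCCCCc2ccccc2)n(C)c2ccc(Cl)cc12` is hydroxy in place of hydrogen on a saturated chain carbon bound to an aromatic carbon and a saturated chain carbon. Among the compounds with values here, two measured steps bear on it. Removing that hydroxy, a 3.2-fold lower number from compound 1 to compound 3 (0.50 log units; beyond the scatter), so the hydroxy in the configuration drawn in compound 1 costs a modest amount. Inverting both stereocentres, a 2000-fold higher number from compound 1 to compound 2 (3.30 log units; beyond the scatter), a large loss; the only structural fact behind it is the fact that compounds 1 and 2 differ only in the configuration as drawn, and the data do not separate the share of the chain stereocentre from that of the carbinol. Compound 4 carries the chain stereocentre of compound 1 and compound 3 but the carbinol configuration drawn in compound 2, so the outcome depends on which centre drives the large step.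

On balance a loss beyond the scatter is expected, a 33-fold higher number from compound 3 to compound 4 (1.52 log units; beyond the scatter), with wide uncertainty. Compound 4 is estimated at 4 nM in this assay, within 0.4 nM to 100 nM.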

Compound 4, half-maximal inhibitory concentration: 260 nM
Beside the measured number, compound 4's estimate is 65-fold (1.81 log units) below it; measured number outside the range, above it.
By their numbers in this assay, from the lowest: compound 3; then compound 1; then compound 4; then compound 2.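

Hydroxy in place of hydrogen on a saturated chain carbon bound to an aromatic carbon and a saturated chain carbon does not carry one fixed, modest cost: in the configuration drawn in compound 4 it gives a 2200-fold higher number from compound 3 to compound 4 (3.34 log units; beyond the scatter), so the size of this change depends on the configuration at that carbon. Inverting that carbon alone gives a 680-fold higher number from compound 1 to compound 4 (2.84 log units; beyond the scatter), whereas inverting only the other stereocentre gives a 2.9-fold lower number from compound 2 to compound 4 (0.46 log units; beyond the scatter), so most of the large gap between compound 1 and compound 2 lies at the hydroxy-bearing carbon. That split rests on two pairs that each differ at a single stereocentre, the first of them being decisive here: the fact that compounds 1 and 4 differ only in the configuration as drawn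

Going by these compounds, the effect of the other stereocentre is read here only with the hydroxy configuration of compound 4, and how it acts with the hydroxy configuration of compound 1 or with hydrogen at that carbon remains open. Also open, on these data alone, is whether a methoxy group, an amine or a fluorine at that carbon would stay close to compound 3 or fall towards compound 4.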